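Nitrile arm length and potency across a three-compound series

The source may report more compounds than this note shows. Statements on the series, on what has been measured and on what is new or still open speak of the compounds shown alone.

Compound 1 `N#CCCn1nc(-c2ccc(OCc3ccccc3)cc2)oc1=O`: in an assay for inhibition of Amine oxidase [flavin-containing] B (Rattus norvegicus) (a lower number here means a stronger inhibitor, a higher number a weaker inhibitor), compound 1 gives 2.2 nM.
Compound 2 `N#CCn1nc(-c2ccc(OCc3ccccc3)cc2)oc1=O`: in this assay compound 2 gives 60 nM.
Compound 3 `N#CCCCn1nc(-c2ccc(OCc3ccccc3)cc2)oc1=O`: in this assay compound 3 gives 410 nM.

Compound 3 stands highest of the three numbers in this assay; its nearest neighbour is compound 2, separated by a 6.8-fold higher number from compound 2 to compound 3 (0.83 log units; beyond the scatter), and its furthest is compound 1, separated by a 190-fold higher number from compound 1 to compound 3 (2.27 log units; beyond the scatter). Compound 4 `N#CCCCCn1nc(-c2ccc(OCc3ccccc3)cc2)oc1=O` lengthens the chain once more: cyanomethyl in place of cyano on a saturated chain carbon, three bonds along the chain from an aromatic nitrogen. Among the measured compounds shown here, two measured steps bear on this. The same exchange one bond closer to the aromatic nitrogen gave a 190-fold higher number from compound 1 to compound 3 (2.27 log units; beyond the scatter), a large rise, and the shorter exchange gave a 6.8-fold higher number from compound 2 to compound 3 (0.83 log units; beyond the scatter), a modest one. Shortening below compound 1 also raised the number, a 27-fold higher number from compound 1 to compound 2 (1.44 log units; beyond the scatter). A further rise beyond the scatter is therefore expected, estimated as a 6.1-fold higher number from compound 3 to compound 4 (0.79 log units; beyond the scatter). Compound 4 is expected to give 2500 nM in this assay, with a range from 600 nM to 12000 nM.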

Compound 4, half-maximal inhibitory concentration: 490 nM
Compound 4: the middle estimate sits 5.1-fold (0.71 log units) above what was measured; the whole stated range lies above it.
By their numbers in this assay, from the lowest: compound 1; then compound 2; then compounds 3 and 4 (each within the scatter of the next).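

The 4-cyanobutyl arm cannot be told apart from the 3-cyanopropyl arm in this assay: a 1.2-fold higher number from compound 3 to compound 4 (0.08 log units; within the scatter). The 4-cyanobutyl arm still stands clear of the two shorter arms, with an 8.2-fold higher number from compound 2 to compound 4 (0.91 log units; beyond the scatter) and a 220-fold higher number from compound 1 to compound 4 (2.35 log units; beyond the scatter), so the low number stays confined to the 2-cyanoethyl arm of compound 1, while the two longest arms sit level. One chain carbon more or less therefore carries no fixed step size: the same change on two cores in this assay, a 27-fold higher number (1.44 log units; beyond the scatter) from compound 1 to compound 2 and a 1.2-fold lower number (0.08 log units; within the scatter) from compound 4 to compound 3, 33-fold (1.51 log units) apart, beyond the scatter of two such steps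

Going by these compounds, whether a longer chain stays at this level remains open. Also open, on these data alone, is whether an amine or a carboxylic acid in place of the nitrile would match the 2-cyanoethyl arm.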